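From phenyl to furan-2-yl on compound 2

The source may report more compounds than this note shows. Statements on the series, on what has been measured and on what is new or still open speak of the compounds shown alone.

Two compounds have values in a functional assay on MCF7 cells (Homo sapiens) for inhibition, read by CCK-8 assay, with a stated time of 48 h (on this read-out higher numbers stand for weaker inhibition of growth and lower numbers for stronger inhibition of growth), so far:

- compound 1 `Cc1ccccc1Nc1nc(Nc2ccc(N3CCN(C(=O)OC(C)(C)C)CC3)cc2)ncc1Cl` gives 2250 nM
- compound 2 `CN1CCN(c2ccc(Nc3ncc(Cl)c(NCc4ccccc4)n3)nc2)CC1` gives 17300 nM

Compound 2 holds the higher of the two numbers (17300 nM) and so shows the weaker inhibition of growth, a gap to compound 1 that lies beyond the scatter. Going by the values given here, no two measured compounds differ in one place only, so no measured step guides what follows.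

Compound 3 `CN1CCN(c2ccc(Nc3ncc(Cl)c(NCc4ccco4)n3)nc2)CC1` departs from compound 2 by a single change, furan-2-yl in place of phenyl on a saturated chain carbon bound to a nitrogen on an aromatic ring. Among the compounds with values here, with no measured precedent, no shift beyond the scatter is expected in this assay, only a slight lean to lower numbers, an estimated 1.2-fold lower number from compound 2 to compound 3 (0.06 log units; within the scatter) on this reading. Compound 3 is therefore expected near 15000 nM, with the range estimated to run from 6500 nM to 35000 nM in this assay.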

Compound 3, concentration for 50% growth inhibition: 21300 nM
Compound 3: the middle estimate sits 1.4-fold (0.15 log units) below what was measured; measured number inside the range.
By their numbers in this assay, from the lowest: compound 1; then compounds 2 and 3 (each within the scatter of the next).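

In this assay, going by these compounds alone, the first single change gives a 1.2-fold higher number from compound 2 to compound 3 (0.09 log units; within the scatter), so furan-2-yl and phenyl cannot be told apart at this place, on a saturated chain carbon bound to a nitrogen on an aromatic ring. Here a six-membered aromatic ring of carbon only gives way to a five-membered aromatic ring with 1 hetero atom, and the added hydrogen-bond acceptor brings no shift beyond the scatter. Nothing measured here offers a reason for this result.

From the compounds shown here alone, whether a ring is needed on this chain carbon at all stays open, as does what pyridin-3-yl, cyclohexyl or a plain methyl group would do there. Also open, going by these compounds, is whether a longer chain, as in 2-phenylethyl in place of benzyl, would move the number beyond the scatter.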